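The source may hold more compounds than are shown below. What is called first, only, known or untested is meant among the compounds shown, and "the series" means these compounds.

Measured compounds in an assay on isolated protein for inhibition of Nitric oxide synthase, inducible (Homo sapiens), with a stated time of 30 min, tested at 1 mM; on this read-out higher numbers stand for more inhibition at the one concentration tested (going by the name of the read-out) and lower numbers for less inhibition:
compound 1 `COc1cc(N)c(C2=NN(C(=O)CCc3ccccc3)CC2)cc1OC`: 23.7%
compound 2 `COc1cc(N)c(C2=NN(C(=O)C3CC3)CC2)c(OC)c1OC`: 30.1%
compound 3 `COc1cc(N)c(C2=NN(C(=O)c3ccccc3)CC2)c(OC)c1OC`: 8.14%

Compound 3 stands lowest of the three numbers in this assay, beyond the scatter from both compound 1 and compound 2. Among the measured compounds shown here, the only step at the carbonyl carbon, a number 22 percentage points lower from compound 2 to compound 3 (beyond the scatter), shows the phenyl amide giving the smallest number.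

Compound 4 `COc1cc(N)c(C2=NN(C(=O)CCc3ccccc3)CC2)c(OC)c1OC` differs from compound 3 as follows: phenethyl in place of phenyl on a carbonyl carbon. For the measured compounds named here, no measured step exchanges phenyl for phenethyl. Compound 1 carries the same phenethyl amide on a core with one methoxy fewer, and in this assay compound 1 gives 23.7%. Compound 4 is therefore expected to move up from compound 3, by about a number 13.9 percentage points higher from compound 3 to compound 4 (beyond the scatter). The estimate for compound 4 is 22%, expected between 8% and 36%.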

Compound 4, a percentage reported as inhibition, at one concentration (the size of the read-out at that concentration, not a potency): 18.3%
Compound 4: middle estimate off by 3.7 percentage points, on the high side; the range from low to high includes it.
By their numbers in this assay, from the lowest: compound 3; then compounds 4, 1 and 2 (each within the scatter of the next, the first and the last beyond it).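

On the shared core, phenethyl on the carbonyl carbon sits above phenyl in this assay, a number 10.2 percentage points higher from compound 3 to compound 4 (beyond the scatter), but below cyclopropyl, a number 11.8 percentage points lower from compound 2 to compound 4 (beyond the scatter). With the phenethyl amide, methoxy in place of hydrogen on an aromatic carbon does not separate the two compounds: a number 5.4 percentage points lower from compound 1 to compound 4 (within the scatter). No evidence is available on what underlies these differences.

Open, from the compounds shown here alone, is how a benzyl group, or a chain ending in an amine or a carboxylic acid, would read on the carbonyl carbon. Also open, going by these compounds, is whether the methoxy step holds with cyclopropyl or phenyl there.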